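Working notes: an aryl-for-alkyl swap on the aniline nitrogen

This account rests on a few compounds, and the source may have more. Where it says the series, first, only, none or still open, it means among the compounds named here.

Of the compounds shown here, three have been measured in a physicochemical assay for lipophilicity, using the shake flask method, measured as octanol-water partition, with a stated time of 24 h, at 25 degrees C; on this read-out higher numbers stand for higher lipophilicity and lower numbers for lower lipophilicity. Compound 2 `CCCCCCCCN(Cc1nnn[nH]1)c1ccccc1` stands highest of the three numbers, giving 2.24. Compound 1 `COc1ccc(N(Cc2nnn[nH]2)Cc2ccc(Cl)cc2Cl)cc1` gives 1.58, a number that is lower than that of compound 2 by a margin beyond the scatter. Compound 3 `Cc1ccc(N(Cc2nnn[nH]2)Cc2ccc(F)cc2F)cc1` gives 1.42, the furthest from compound 2, again beyond the scatter. Compound 1 and compound 3 lie within the scatter of each other, so nothing is said about their order.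

Compound 4 `Clc1ccccc1CN(Cc1nnn[nH]1)c1ccccc1` has not been measured. It differs from compound 2 in one place: 2-chlorophenyl in place of heptyl on a saturated chain carbon bound to a nitrogen on an aromatic ring.

Within the data shown here, no measured pair shows this change on its own, so the expectation rests on the values shown. Since compound 1 gives 1.58 and compound 3 gives 1.42, each carrying a substituted benzyl group on that nitrogen, a downward step beyond the scatter is expected for compound 4. The step from compound 2 to compound 4 is estimated as a number 0.74 log units lower from compound 2 to compound 4 (beyond the scatter). Compound 4 is therefore estimated at 1.5, in a range from 1.1 to 1.9.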

Compound 4, partition coefficient: 1.09
Estimate against measurement, compound 4: 0.41 log units above, outside the stated range (below it).
By their numbers in this assay, from the lowest: compound 4; then compounds 3 and 1 (each within the scatter of the next); then compound 2.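

In this assay, among these compounds, the first comparison that changes one place only gives a number 1.15 log units lower from compound 2 to compound 4 (beyond the scatter), a large step for 2-chlorophenyl in place of heptyl on a saturated chain carbon bound to a nitrogen on an aromatic ring. The step shows that this position responds strongly to the change, although the entering and leaving groups both count 7 heavy atoms and neither carries a hydrogen-bond donor or acceptor. Nothing at hand accounts for the size of the step.

Whether the step follows the aromatic ring, the chlorine or the loss of the open chain stays undecided, since the two groups differ in all three at once. Cyclohexyl, unsubstituted phenyl or a shorter chain such as butyl at this position would separate these readings, and a carboxylic acid would test a charged group there.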